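Urea series on the shared core: aryl to cyclohexyl

The source may report more compounds than this note shows. Statements on the series, on what has been measured and on what is new or still open speak of the compounds shown alone.

Two ureas sharing one core have been measured. Compound 1 `COc1ccc(NC(=O)Nc2cccc(CNc3nccnc3Cl)c2)cc1` gives 12000 nM in a functional assay on HepG2 cells (Homo sapiens) for antiproliferative activity, read by MTT assay, with a stated time of 48 h; a higher number here means a weaker inhibitor, a lower number a stronger inhibitor; compound 2 `O=C(Nc1ccc(Cl)cc1)Nc1cccc(CNc2nccnc2Cl)c1` gives 8350 nM. Within the data shown here, the only step recorded, a 1.4-fold lower number from compound 1 to compound 2 (0.16 log units; within the scatter), changes a substituent on the aromatic ring and stays within the scatter. On these two numbers compound 2 stands lowest, with compound 1 nearest and within the scatter of it.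

Compound 3 `O=C(Nc1cccc(CNc2nccnc2Cl)c1)NC1CCCCC1` keeps the urea and the core and differs from compound 2 by cyclohexyl in place of 4-chlorophenyl on an amide-type nitrogen. Among the measured compounds shown here, no measured step exchanges the aromatic ring itself for a non-aromatic one, so the recorded step bears only loosely on this change: it shows that altering this end of the molecule between chloro and methoxy moved this assay little. Given that, no step beyond the scatter is expected, with the range left wide because the ring type itself is untested; the expected step is a 1.2-fold higher number from compound 2 to compound 3 (0.08 log units; within the scatter). Compound 3 is estimated at 10000 nM, between 3000 nM and 35000 nM.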

Compound 3, half-maximal inhibitory concentration: > 40000 nM
Compound 3: a limit, no number; the forecaster's own chance of this, stated with the estimate: 10%; middle value at least 4.0-fold (0.60 log units) away from the limit.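

Compound 3 has a limit in this assay, not a number: the limit of > 40000 nM in this assay, at which 1 of the 3 values shown sits.

This end of the urea is not as tolerant as the chloro and methoxy exchange suggested, for which the step of a 1.4-fold lower number from compound 1 to compound 2 (0.16 log units; within the scatter) stayed within the scatter. Replacing the substituted aromatic ring with cyclohexyl gives an at least 4.7-fold higher number from compound 2 to compound 3 (0.68 log units; beyond the scatter), and likewise an at least 3.3-fold higher number from compound 1 to compound 3 (0.52 log units; beyond the scatter), so among these three compounds only those with an aromatic ring on this nitrogen give a numeric value. From the compounds shown here alone, the true size of both steps remains unknown, as each rests on the limit.

Going by these compounds, it remains open whether aromaticity itself or something specific to cyclohexyl separates these compounds; an unsubstituted phenyl, a benzyl group or a straight butyl chain on this nitrogen would help to decide. Also open, on these data alone, is whether the urea is needed at all, which an amide in its place would test.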